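Dimethoxyphenyl for chlorophenyl on the triazole nitrogen

This account rests on a few compounds, and the source may have more. Where it says the series, first, only, none or still open, it means among the compounds named here.

For the measured compounds named here, compound 2 `N#CC1=C(N)Oc2c(N)cc3nc4ccccc4nc3c2C12C(=O)N(Cc1cnnn1-c1ccccc1Cl)c1ccccc12` is the only compound of the pair that gives a number in a functional assay on HepG2 cells (Homo sapiens) for antiproliferative activity, read by MTT assay, with a stated time of 48 h; on this read-out higher numbers stand for weaker inhibition and lower numbers for stronger inhibition: compound 2 gives 33500 nM. Compound 1 `Cc1ccc(-n2nncc2CN2C(=O)C3(C(C#N)=C(N)Oc4c3c3nc5ccccc5nc3c3ccccc43)c3ccccc32)c(C)c1` reaches only a limit of this assay, > 50000 nM, which is the limit of > 50000 nM in this assay, at which 1 of the 2 values shown sits. Compound 3 `COc1ccc(OC)c(-n2nncc2CN2C(=O)C3(C(C#N)=C(N)Oc4c(N)cc5nc6ccccc6nc5c43)c3ccccc32)c1` differs from compound 2 in one place: 2,5-dimethoxyphenyl in place of 2-chlorophenyl on an aromatic nitrogen. Going by the values given here, no measured step accompanies this change, so compound 3 is expected to stay close to compound 2, with a step of a 1.2-fold higher number from compound 2 to compound 3 (0.08 log units; within the scatter) that should not exceed the usual scatter. Compound 3 is therefore estimated at 40000 nM, within a range from 15000 nM to 100000 nM.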

Compound 3, half-maximal inhibitory concentration: 45100 nM
Compound 3: middle estimate off by 1.1-fold (0.05 log units), on the low side; measured number inside the range.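

In this assay, for the compounds shown here, 2,5-dimethoxyphenyl in place of 2-chlorophenyl on the aromatic nitrogen gives a 1.3-fold higher number from compound 2 to compound 3 (0.13 log units; within the scatter), the only measured step at this position. The entering group carries hydrogen-bond acceptors that the leaving group lacks, yet the two compounds do not separate on this read-out. Compound 1 remains a limit of the assay, not a number: the limit of > 50000 nM in this assay, at which 1 of the 3 values shown sits.

From the compounds shown here alone, whether an amine or a carboxylic acid on this phenyl ring, or a longer alkyl chain in its place, would move the number beyond the scatter stays open.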